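The source may hold more compounds than are shown below. What is called first, only, known or untested is meant among the compounds shown, and "the series" means these compounds.

Measured in an ADME assay on HFF cells (Homo sapiens) for cytotoxicity, read by neutral red uptake; a higher number here means that more compound is tolerated, a lower number that less compound is tolerated:
Compound 1 `Nc1ncnc2c1ncn2/C=C1\C[C@@H]1[C@H](O)CO`: > 300000 nM (a limit of the assay, not a number)
Compound 2 `Nc1nc2c(ncn2/C=C2/C[C@H]2[C@@H](O)CO)c(=O)[nH]1`: 299000 nM

Compound 1 has no exact reading in this assay, and its > 300000 nM is only a limit. The top of the measured range is the limit of > 300000 nM in this assay, at which 1 of the 2 values shown sits.

Compound 3 `Nc1ncnc2c1ncn2/C=C1/C[C@H]1[C@@H](O)CO` has the same atoms and bonds as compound 1 and differs only in configuration as drawn: the two compounds have the same atoms and bonds and differ only in configuration as drawn: 3 of 3 stereo elements differ; a stereocentre at a saturated ring carbon is drawn S in compound 1 and R in compound 3; a stereocentre at a saturated chain carbon is drawn S in compound 1 and R in compound 3; a double bond is drawn E in compound 1 and Z in compound 3. A stereocentre at a saturated ring carbon is drawn R instead of S, a stereocentre at a saturated chain carbon is drawn R instead of S, and the double bond is drawn Z instead of E.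

Going by the values given here, no measured pair shows what such a change does here. Compound 2 gives 299000 nM, so only very high tolerated concentrations have been seen so far. The expected step of an at least 1.2-fold lower number from compound 1 to compound 3 (0.07 log units; that floor lies within the scatter) therefore stays within the usual scatter, and compound 3 may also reach only the limit. For compound 3 the estimated value is 250000 nM, with an expected range from 100000 nM to 300000 nM.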

Compound 3, half-maximal cytotoxic concentration: 194000 nM
For compound 3 the middle estimate is 1.3-fold (0.11 log units) above the measured one; the range from low to high includes it.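

In this assay, going by these compounds alone, this is the first pair to show what a change in configuration alone does to the tolerated concentration, giving an at least 1.5-fold lower number from compound 1 to compound 3 (0.18 log units; that floor lies within the scatter). No group enters or leaves, so the step can only come from the drawn configuration: the fact that compounds 1 and 3 differ only in the configuration as drawn. On these data alone, compound 1 has only a limit, so this step is a floor and its true size stays unknown: the limit of > 300000 nM in this assay, at which 1 of the 3 values shown sits.

The ring stereocentre, the chain stereocentre and the double bond all change together here, and these compounds do not tell which of them carries the step, or whether all three are needed. Also open, as far as these compounds go, is how a compound carrying a new group, such as a carboxylic acid or a longer chain, would behave in this assay.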